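The source may report more compounds than this note shows. Statements on the series, on what has been measured and on what is new or still open speak of the compounds shown alone.

Compound 3 `O=C(CCCCCCc1ccccc1)c1ncc(-c2nnn[nH]2)o1` gives 63 nM in an assay (Rattus norvegicus) for inhibition of Fatty-acid amide hydrolase 1 (Homo sapiens) (on this read-out lower numbers stand for stronger inhibition and higher numbers for weaker inhibition), the lowest of the three numbers shown, though compound 2 `Nc1ccc(-c2cnc(C(=O)CCCCCCc3ccccc3)o2)cc1` with 90 nM sits within the scatter of it; compound 1 `COc1ccccc1-c1cnc(C(=O)CCCCCCc2ccccc2)o1` gives 400 nM. Compound 4 `O=C(CCCCCCc1ccccc1)c1ncc(C(=O)N2CCOCC2)o1` carries (morpholin-4-yl)carbonyl in place of 1H-tetrazol-5-yl on an aromatic carbon. The measured steps at this carbon are a 6.3-fold lower number from compound 1 to compound 3 (0.80 log units; beyond the scatter) and a 1.4-fold lower number from compound 2 to compound 3 (0.15 log units; within the scatter): one swap of the group here moved the number beyond the scatter, the other did not. Among the compounds with values here, a carbonyl-linked non-aromatic ring has no measured counterpart, so the direction is open; only a modest step in this assay, if any, is expected, leaning towards a higher number. For compound 4 the estimate is 150 nM, range 40 nM to 600 nM, meaning a 2.4-fold higher number from compound 3 to compound 4 (0.38 log units; beyond the scatter).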

Compound 4, inhibition constant: 24 nM
Compound 4: the middle estimate sits 6.3-fold (0.80 log units) above what was measured; measured number outside the range, below it.
By their numbers in this assay, from the lowest: compound 4; then compounds 3 and 2 (each within the scatter of the next); then compound 1.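

Against the other groups at this carbon, a 2.6-fold lower number from compound 3 to compound 4 (0.42 log units; beyond the scatter) and a 3.8-fold lower number from compound 2 to compound 4 (0.57 log units; beyond the scatter) and a 17-fold lower number from compound 1 to compound 4 (1.22 log units; beyond the scatter) all lie beyond the scatter in this assay and leave compound 4 with the lowest number of the series. An aromatic ring directly on this carbon is therefore not needed for a low number, since a non-aromatic ring joined through a carbonyl goes lower. The data shown offer no measured explanation for this step.

From the compounds shown here alone, whether the carbonyl or the morpholine ring drives the step remains open. A piperidine amide, a dimethylamide, an ester or a carboxylic acid at this carbon would separate the two.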